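Adding one fluoro to compound 2

The compounds below may be only part of what the source reports. "The series", "measured", "known", "first", "only" and "open" are said of these compounds alone.

In an ADME assay on MT4 cells (Homo sapiens) for cytotoxicity, read by MTT assay, with a stated time of 5 days (on this read-out lower numbers stand for higher toxicity in this test and higher numbers for lower toxicity in this test), compound 1 `N#Cc1ccc(Nc2nccc(OCC(=O)Nc3ccc(Cl)cc3)n2)cc1` gives 162000 nM. Compound 2 `N#Cc1ccc(NC(=O)COc2ccnc(Nc3ccc(C#N)cc3)n2)cc1` gives > 337000 nM, which is a limit of the assay and not a number. Compound 2 thus stands at the limit of > 337000 nM in this assay, at which 1 of the 2 values shown sits.

The next structure, compound 3 `N#Cc1ccc(Nc2nccc(OCC(=O)Nc3ccc(C#N)cc3F)n2)cc1`, differs from compound 2 in one place: fluoro in place of hydrogen on an aromatic carbon. This is fluoro in place of hydrogen on an aromatic carbon, which turns a 4-cyanophenyl into a 4-cyano-2-fluorophenyl.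

For the measured compounds named here, only one measured step offers any guidance: an at least 2.0-fold higher number from compound 1 to compound 2 (0.31 log units; beyond the scatter), with cyano in place of chloro on an aromatic carbon. Going by the values given here, that is a different swap, and no measured pair shows fluoro entering, so it bears on the new change only loosely. No step beyond the usual scatter is therefore expected in this assay, and compound 3 may also end at a limit of the assay. The expected change is an at least 1.1-fold lower number from compound 2 to compound 3 (0.05 log units; that floor lies within the scatter). For compound 3 the estimated value is 300000 nM, with an expected range of 110000 nM to 400000 nM.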

Compound 3, half-maximal cytotoxic concentration: > 321000 nM
Compound 3: only a limit was reported; the forecaster's own chance of this, stated with the estimate: 60%; at least 1.0-fold (0.02 log units) between middle value and limit.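

In this assay compound 3 gives > 321000 nM, which is a limit of the assay and not a number. Compound 2 also ended at a limit, so the step between these two compounds cannot be read, but the new result does show that adding a fluoro to this aromatic ring, ortho to a large group and meta to the cyano group, still leaves the compound at a limit instead of giving a measured value like that of compound 1. The comparison that can be read gives an at least 1.9-fold higher number from compound 1 to compound 3 (0.29 log units; that floor lies within the scatter), and with its floor inside the usual scatter, it does not by itself establish a real difference between the 4-cyano-2-fluorophenyl and 4-chlorophenyl groups.

With both compounds at limits, the compounds shown leave open whether the fluoro changes toxicity in this test at all, and by how much. They also leave open whether a larger group at the same place, such as a methoxy or an amine, would bring the read-out down to a measurable number.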